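Aryl substituent change on the thiourea series

The compounds below may be only part of what the source reports. "The series", "measured", "known", "first", "only" and "open" are said of these compounds alone.

Compound 3 `COc1cc(/C=C/C(=O)C2=C(/C=C/c3ccc(O)c(OC)c3)NC(=S)NC2c2ccccc2)ccc1O` stands second of the three numbers in a functional assay, with a stated time of 20 min, tested at 10 uM (a higher number here means a stronger effect of the compound at the concentration tested, a lower number a weaker effect), where compound 3 gives 26.5%. Its nearest neighbour is compound 2 `COc1cc(/C=C/C(=O)C2=C(/C=C/c3ccc(O)c(OC)c3)NC(=O)NC2c2c(Cl)cccc2Cl)ccc1O`, which in this assay gives 19.2%, a gap within the scatter. Among the measured compounds shown here, the furthest is compound 1 `COc1cc(/C=C/C(=O)C2=C(/C=C/c3ccc(O)c(OC)c3)NC(=O)NC2c2ccccc2O)ccc1O`, which in this assay gives 73.6%; compound 1 differs from compound 3 in two places at once, so the pair shows only that the two values lie well apart.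

Compound 4 `COc1cc(/C=C/C(=O)C2=C(/C=C/c3ccc(O)c(OC)c3)NC(=S)NC2c2ccc(N(C)C)cc2)ccc1O` is unmeasured. It differs from compound 3 by dimethylamino in place of hydrogen on an aromatic carbon.

For the measured compounds named here, the only single-step comparison is a number 54.4 percentage points lower from compound 1 to compound 2 (beyond the scatter). Going by the values given here, that step concerns an exchange of the whole aryl group on the saturated ring carbon within the urea branch and does not test a dimethylamino group, so no measured step bears directly on the change from compound 3 to compound 4. Without a precedent, a step of no clear direction beyond the scatter is expected, with wide uncertainty.

For compound 4 in this assay the value is estimated at 30%, in the range 10% to 55%, corresponding to an expected step of a number 3.5 percentage points higher from compound 3 to compound 4 (within the scatter).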

Compound 4, a percentage reported as activity, at one concentration (the size of the read-out at that concentration, not a potency): 72%
Beside the measured number, compound 4's estimate is 42 percentage points below it, outside the stated range (above it).
By their numbers in this assay, from the lowest: compounds 2 and 3 (each within the scatter of the next); then compounds 4 and 1 (each within the scatter of the next).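

On the thiourea branch, dimethylamino in place of hydrogen on an aromatic carbon, para to a large group, moves the read-out in this assay by a large margin: a number 45.5 percentage points higher from compound 3 to compound 4 (beyond the scatter). The earlier step, a number 54.4 percentage points lower from compound 1 to compound 2 (beyond the scatter), exchanged the whole aryl group within the urea branch and could not assign an effect to one aromatic carbon, whereas this pair isolates a single substitution and shows that the read-out is sensitive to a change at this position. Nothing measured here bears on the origin of this step.

On these data alone, it remains open whether the step is specific to dimethylamino or would also appear with a plain amino group, a carboxylic acid or a longer chain on the same aromatic carbon. The compounds shown also leave open whether the same change from phenyl to 4-(dimethylamino)phenyl would give a step of similar size on the urea branch, since the thiourea pair is the only direct test of this change.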